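A few compounds are considered here, and "the series" means these few. Any claim that something is new, unique, unknown or untested is made for them only; others in the source may bear on it.

Working notes on the series. Going by the values given here, compound 1 `B[P@@](=O)(OC[C@H]1O[C@@H](n2cc(OC)c(=O)[nH]c2=O)[C@H](O)[C@@H]1O)OP(=O)(O)O` is the reference point here: in an in vitro functional assay on 1321-N1 cells for agonist activity at P2Y purinoceptor 6 (Homo sapiens), read by fluorescence, spectrophotometry and calcium flux (on this read-out lower numbers stand for an effect already at smaller amounts and higher numbers for an effect only at larger amounts of compound), compound 1 gives 8 nM, the lowest of the two numbers measured so far. Among the compounds with values here, its diastereomer compound 2 `B[P@](=O)(OC[C@H]1O[C@@H](n2cc(OC)c(=O)[nH]c2=O)[C@H](O)[C@@H]1O)OP(=O)(O)O` gives 4300 nM in this assay; the step of a 540-fold higher number from compound 1 to compound 2 (2.73 log units; beyond the scatter) is the only measured step, and it rests on (the fact that compounds 1 and 2 differ only in the configuration as drawn), a change in configuration at the phosphorus and nothing else.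

Compound 3 `B[P@@](=O)(OC[C@H]1O[C@@H](n2cc(OC)c(=O)[nH]c2=O)[C@H](O)[C@@H]1O)OP(=O)(O)OP(=O)(O)O` keeps the configuration of compound 1 and differs from it by a group of 4 heavy atoms (3 oxygen, 1 phosphorus; no ring) in place of a hydrogen atom, on an oxygen; the chain thus grows by one phosphate unit at the end. Within the data shown here, no measured step bears on this kind of change: the step from compound 1 to compound 2 concerns configuration only, not chain length, so it gives no guidance on size or direction for the present step. The expectation is therefore an estimate with a wide range rather than an extrapolation. In this assay compound 3 is expected at 120 nM, between 12 nM and 1500 nM, which would mean a step of a 15-fold higher number from compound 1 to compound 3 (1.18 log units; beyond the scatter).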

Compound 3, half-maximal effective concentration: 11200 nM
Compound 3: middle estimate off by 93-fold (1.97 log units), on the low side; measured number outside the range, above it.
By their numbers in this assay, from the lowest: compound 1; then compound 2; then compound 3.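

On this oxygen, whose other neighbour is phosphorus, this assay responds strongly to added size: a group of 4 heavy atoms (3 oxygen, 1 phosphorus; no ring) in place of a hydrogen atom gives a 1400-fold higher number from compound 1 to compound 3 (3.15 log units; beyond the scatter). The earlier pair showed only that configuration at phosphorus matters, with a 540-fold higher number from compound 1 to compound 2 (2.73 log units; beyond the scatter); the chain length at this oxygen now proves to be a second place where one change gives a large step, and compound 3 shows that keeping the configuration of compound 1 does not by itself preserve the low number. Nothing recorded for the series accounts for the size of this step.

The compounds shown leave open whether a smaller group on this oxygen, such as methyl, would give a step of similar size, or whether an ethyl group or a still longer phosphate chain would continue in the same direction. They also leave open how the configuration at phosphorus acts once the chain carries the added phosphate unit, since the longer chain appears here with only one configuration.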